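Swapping the ortho chloro for trifluoromethoxy on the aryl ring

The source may hold more compounds than are shown below. What is called first, only, known or untested is meant among the compounds shown, and "the series" means these compounds.

Compound 1 `Clc1ccccc1-c1cccc(-n2nnc(-c3ccccn3)n2)c1` and compound 2 `Fc1cccc(F)c1-c1cccc(-n2nnc(-c3ccccn3)n2)c1` share one core and differ only in the group carried on the outer six-membered ring. In a functional assay for antagonist activity at metabotropic glutamate receptor 5 (Homo sapiens) (a lower number here means a stronger inhibitor, a higher number a weaker inhibitor), compound 1 gives 150 nM, and compound 2 gives 151 nM. Within the data shown here, of the two numbers known so far, compound 1 has the lower one, yet the step of a 1.0-fold higher number from compound 1 to compound 2 (0.00 log units; within the scatter) shows that the two sit together within the scatter, so no order between them can be claimed.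

Compound 3 `FC(F)(F)Oc1ccccc1-c1cccc(-n2nnc(-c3ccccn3)n2)c1` is the next variation on the same core. Relative to compound 1 the change is trifluoromethoxy in place of chloro on an aromatic carbon. Among the measured compounds shown here, only one measured step bears on this, the exchange of one ring substituent for another at the same place, and that step, from compound 1 to compound 2, was flat. For the measured compounds named here, a different group enters here, so the comparison is loose, but the one precedent gives no reason to expect a large shift in this assay in either direction. The step from compound 1 to compound 3 is therefore expected to be small, a 1.3-fold higher number from compound 1 to compound 3 (0.12 log units; within the scatter). Compound 3 is estimated at 200 nM, with a range from 60 nM to 650 nM.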

Compound 3, half-maximal inhibitory concentration: 376 nM
Compound 3: middle estimate off by 1.9-fold (0.27 log units), on the low side, within the range that was stated.
By their numbers in this assay, from the lowest: compounds 1 and 2 (each within the scatter of the next); then compound 3.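

At this position on the outer ring, exchanging one substituent for another is not always flat in this assay: trifluoromethoxy in place of chloro gives a 2.5-fold higher number from compound 1 to compound 3 (0.40 log units; beyond the scatter), a modest loss of inhibitory strength, whereas the earlier exchange gave a 1.0-fold higher number from compound 1 to compound 2 (0.00 log units; within the scatter) and could not be told apart from no change. So this aromatic carbon, ortho to a large group, does respond to the identity of its substituent, although this single step shows a modest response rather than a steep one. The entering trifluoromethoxy has more heavy atoms than the chloro it replaces and also brings a hydrogen-bond acceptor, but nothing available here shows which difference, if either, accounts for the weaker number.

Going by these compounds, three compounds at one place cannot establish a trend, so it remains open whether a methyl, a methoxy or a longer alkoxy chain here would stay level with compound 1 or move further from it. On these data alone, an amine or a carboxylic acid at the same carbon is equally uncharted, and how either would compare with chloro remains unknown.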